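This account rests on a few compounds, and the source may have more. Where it says the series, first, only, none or still open, it means among the compounds named here.

This series shares one core, a fused two-ring system carrying a sulfonyl-linked aromatic group and an amine substituent. Compound 1 `CC1CCN(c2c(S(=O)(=O)c3ccc(Cl)c(Cl)c3)cnc3ccc(Cl)cc23)CC1` bears a 4-methylpiperidin-1-yl group together with chlorine substituents on both aromatic parts; compound 2 `CCN(CC)c1c(S(=O)(=O)c2ccc(C)cc2)cnc2ccccc12` carries a diethylamino group and a methyl-substituted aromatic ring. In an assay on isolated protein for displacement of a labelled ligand from metabotropic glutamate receptor 5 (Homo sapiens), with a stated time of 60 min (on this read-out lower numbers stand for stronger inhibition and higher numbers for weaker inhibition), compound 1 gives 55.6 nM and compound 2 gives 201 nM.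

Compound 3 `CN1CCN(c2c(S(=O)(=O)c3ccccc3)cnc3ccccc23)CC1` has a 4-methylpiperazin-1-yl group and no further substituents. In this assay compound 3 is recorded as "not determined" (no result reported), so its position on the numbers cannot be stated.

Compound 4 `CC1CCN(c2c(S(=O)(=O)c3ccccc3)cnc3ccccc23)CC1` is the unmeasured partner of compound 3. The change between them is 4-methylpiperidin-1-yl in place of 4-methylpiperazin-1-yl on an aromatic carbon.

Within the data shown here, since compound 3 itself has no number, there is no measured pair here from which the size of this step in this assay can be read, and no direction can be assigned to it beyond what the two measured compounds suggest. Compound 1, which shares the 4-methylpiperidin-1-yl group, gives 55.6 nM, and the simpler compound 2 gives 201 nM. The value of compound 4 is expected to be 150 nM, within a range from 40 nM to 600 nM.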

Compound 4, inhibition constant: 108 nM
Compound 4: middle estimate off by 1.4-fold (0.14 log units), on the high side, and the stated range covers the measured number.
By their numbers in this assay, from the lowest: compounds 1, 4 and 2 (each within the scatter of the next, the first and the last beyond it).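

No step can be read between compound 3 and compound 4 in this assay as this assay gives no result for compound 3. Going by these compounds, what swapping 4-methylpiperazin-1-yl for 4-methylpiperidin-1-yl does to binding on this shared core therefore stays open. Nothing shown here offers an explanation for the values.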